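The source may hold more compounds than are shown below. What is called first, only, known or untested is meant among the compounds shown, and "the series" means these compounds.

Measured so far in an assay on membranes from brain for binding affinity to Neuronal acetylcholine receptor; alpha4/beta2 (Rattus norvegicus); on this read-out higher numbers stand for weaker inhibition and lower numbers for stronger inhibition:

compound 1, `CN1CCC[C@H]1COc1cncc(-c2ccccc2)c1`: 0.11 nM
compound 2, `CN1CCC[C@H]1COc1cncc(-c2ccc(C(F)(F)F)cc2)c1`: 0.15 nM

Among the measured compounds shown here, compound 2 holds the highest of the two numbers; its nearest neighbour is compound 1, and the only measured step, a 1.4-fold higher number from compound 1 to compound 2 (0.13 log units; within the scatter), lies within the scatter. So the two measured compounds cannot be ordered against each other on this assay.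

The next step modifies the same position: fluoro in place of trifluoromethyl on an aromatic carbon, giving compound 3, `CN1CCC[C@H]1COc1cncc(-c2ccc(F)cc2)c1`. For the measured compounds named here, the only step that bears on it is the one just named, in which the trifluoromethyl entered in place of hydrogen without moving the number beyond the scatter. Compound 3 carries a fluoro at that same place, a substituent of intermediate size between the hydrogen of compound 1 and the trifluoromethyl of compound 2. With both ends of that range giving numbers within the scatter of each other, no step beyond the scatter is expected in this assay for compound 3; the estimated step is a 1.2-fold lower number from compound 2 to compound 3 (0.06 log units; within the scatter). The value for compound 3 is therefore expected near 0.13 nM, with a range from 0.05 nM to 0.35 nM.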

Compound 3, inhibition constant: 0.11 nM
Compound 3: the middle estimate sits 1.2-fold (0.07 log units) above what was measured; measured number inside the range.
By their numbers in this assay, from the lowest: compounds 1, 3 and 2 (each within the scatter of the next).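

In this assay, fluoro at this aromatic carbon gives a 1.4-fold lower number from compound 2 to compound 3 (0.13 log units; within the scatter) when it replaces trifluoromethyl, and no change at the digits printed from compound 1 to compound 3 (within the scatter) when it replaces hydrogen. The earlier pair gave only two substituents to compare at this place, para to a large group; hydrogen, fluoro and trifluoromethyl now form a set of three, all within the scatter of one another, so this read-out sets no order among them, and a change of one heavy atom or of four at this carbon leaves the number within the scatter in each case. No measurement at hand bears on why these three substituents read alike.

The compounds shown leave open whether the number stays within the scatter with an amine, a carboxylic acid or a longer chain such as butyl at this carbon, since all three substituents so far are hydrogen, fluoro and trifluoromethyl, with no ring, no hydrogen-bond donors and no net charge among the groups exchanged. They also leave open whether fluoro or trifluoromethyl on a different carbon of the same aromatic ring would read as these do in this assay.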